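Replacing Isopropyl with Bromo on the Phenyl Ring

The source may report more compounds than this note shows. Statements on the series, on what has been measured and on what is new or still open speak of the compounds shown alone.

Compound 3 `CC(C)c1ccc(-n2nncc2-c2cn([C@H]3C[C@H](O)[C@@H](CO)O3)c(=O)[nH]c2=O)cc1` reaches only a limit in an ADME assay on CCRF-CEM cells (Homo sapiens) for cytotoxicity, read by cell counting, with a stated time of 3 days; a higher number here means a weaker inhibitor, a lower number a stronger inhibitor: its reading of > 200000 nM is a boundary of the measurement, not a number (the limit of > 200000 nM in this assay, at which 1 of the 3 values shown sits). Compound 2 `O=c1[nH]c(=O)n([C@H]2C[C@H](O)[C@@H](CO)O2)cc1-c1cnnn1-c1c(F)cccc1F` gives 12000 nM in this assay, and compound 1 `O=c1[nH]c(=O)n([C@H]2C[C@H](O)[C@@H](CO)O2)cc1-c1cn(-c2ccc(Cl)cc2)nn1` gives 13000 nM. Going by the values given here, the only measured step, an at least 16-fold higher number from compound 2 to compound 3 (1.22 log units; beyond the scatter), shows that exchanging the group on the aromatic nitrogen can shift the number strongly. Compound 4 `O=c1[nH]c(=O)n([C@H]2C[C@H](O)[C@@H](CO)O2)cc1-c1cnnn1-c1ccc(Br)cc1` differs from compound 3 by bromo in place of isopropyl on an aromatic carbon. The expected step is an at least 10-fold lower number from compound 3 to compound 4 (1.00 log units; beyond the scatter), towards a lower number, because compound 1, carrying chloro instead of isopropyl, gives 13000 nM. For compound 4 the estimate in this assay is 20000 nM, with a range from 6000 nM to 100000 nM.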

Compound 4, half-maximal inhibitory concentration: 47000 nM
Beside the measured number, compound 4's estimate is 2.4-fold (0.37 log units) below it; the measured number falls inside the stated range.
By their numbers in this assay, from the lowest: compounds 2 and 1 (each within the scatter of the next); then compound 4. At a limit, above all of these: compound 3.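

In this assay, bromo in place of isopropyl on an aromatic carbon brings the reading down to a measured number, an at least 4.2-fold lower number from compound 3 to compound 4 (0.62 log units; beyond the scatter). Compound 3 stands at a limit, so this step gives only a smallest possible size: the limit of > 200000 nM in this assay, at which 1 of the 4 values shown sits. With 4-bromophenyl in place of 2,6-difluorophenyl on the aromatic nitrogen, the shift is a 3.9-fold higher number from compound 2 to compound 4 (0.59 log units; beyond the scatter), smaller than the shift seen with 4-isopropylphenyl.

The compounds shown leave open how an amine or a methoxy group in the same place would read. They also leave open whether the number follows the size of the group there.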